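The source may report more compounds than this note shows. Statements on the series, on what has been measured and on what is new or still open speak of the compounds shown alone.

Among the measured compounds shown here, compound 1 `Nc1cc(N)c2nc(-c3ccccc3)c(Oc3ccc(Cl)c(Cl)c3)nc2c1` is the one compound here with a firm number: in a functional assay on 786-0 cells (Homo sapiens) for inhibition, read by sulforhodamine B assay, with a stated time of 48 h (a lower number here means a stronger inhibitor of growth, a higher number a weaker inhibitor of growth), compound 1 gives 44700 nM. Compound 2 `CCOC(=O)[C@H](CCC(=O)O)NC(=O)c1ccc(CNc2nc3cc(N)cc(N)c3nc2-c2ccccc2)cc1` stands at a limit of this assay rather than at a number: compound 2 gives < 100000 nM, which is a limit (the limit of < 100000 nM in this assay, at which 1 of the 2 values shown sits). Compound 3 `Nc1cc(N)c2nc(-c3ccccc3)c(Sc3ccc(Cl)c(Cl)c3)nc2c1` carries (3,4-dichlorophenyl)sulfanyl in place of 3,4-dichlorophenoxy on an aromatic carbon. No measured pair among the compounds shown makes this kind of change, so no size of step is known from the data; the expectation is a step within the usual scatter, in no clear direction. Compound 3 is therefore expected near 40000 nM in this assay, with a range from 15000 nM to 100000 nM. The expected step of a 1.1-fold lower number from compound 1 to compound 3 (0.05 log units; within the scatter) is thus small.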

Compound 3, concentration for total growth inhibition: 61700 nM
For compound 3 the middle estimate is 1.5-fold (0.19 log units) below the measured one, within the range that was stated.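

The earlier compounds shown here held no step of this kind, and now one is known for this place, on an aromatic carbon next to the ring nitrogen. In this assay (3,4-dichlorophenyl)sulfanyl in place of 3,4-dichlorophenoxy gives a 1.4-fold higher number from compound 1 to compound 3 (0.14 log units; within the scatter) so exchanging oxygen for sulfur here leaves the read-out within the scatter. Nothing shown bears on the reason for this step. Still open, as far as these compounds go, is whether an amine in place of that sulfur, or a longer chain before the dichlorophenyl ring, would move the number beyond the scatter.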